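Swapping a carboxamide-bearing aryl for pyridin-4-yl

This account rests on a few compounds, and the source may have more. Where it says the series, first, only, none or still open, it means among the compounds named here.

Compound 1 `CC(c1ccc2ncc(-c3ccc(F)cc3)cc2c1)n1nnc2ncc(-c3ccncc3)nc21`: 14 uL/min
Compound 2 `CC(c1cc2cc(-c3cnn(C)c3)cnc2cc1F)n1nnc2ncc(-c3ccc(C(N)=O)c(F)c3)nc21`: 2 uL/min
Compound 3 `CC(c1c(F)cc2ncc(-c3cnn(C)c3)cc2c1F)n1nnc2ncc(-c3ccc(C(N)=O)c(F)c3)nc21`: 11 uL/min

Of the compounds shown here, three sharing one core have been measured in an ADME assay on microsomes from liver (Homo sapiens) for metabolic stability, read by LC-MS, using NADPH, with stated times of 5 min and 30 min, tested at 1 uM; on this read-out lower numbers stand for slow clearance and higher numbers for fast clearance. For the measured compounds named here, compound 3 gives 11 uL/min, a number that lies within the scatter of compound 1, and far from compound 2: the step of a 5.5-fold higher number from compound 2 to compound 3 (0.74 log units; beyond the scatter) is the only single-point comparison among the measured compounds.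

Compound 4 `CC(c1c(F)cc2ncc(-c3cnn(C)c3)cc2c1F)n1nnc2ncc(-c3ccncc3)nc21` differs from compound 3 in one place: pyridin-4-yl in place of 4-carbamoyl-3-fluorophenyl on an aromatic carbon. Going by the values given here, no measured step covers this exact change. The closest pointer is compound 1, which carries the same pyridin-4-yl group on a different core and gives 14 uL/min, a number that sits within the scatter of compound 3. Among the compounds with values here, the one measured step of a 5.5-fold higher number from compound 2 to compound 3 (0.74 log units; beyond the scatter) concerns a fluoro, not this group, and so only loosely bears on it.

Compound 4 is therefore expected to show a step of a 1.6-fold higher number from compound 3 to compound 4 (0.21 log units; within the scatter), small and within the scatter. The estimate for compound 4 is 18 uL/min, expected to fall between 8 uL/min and 40 uL/min.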

Compound 4, intrinsic clearance in a liver preparation (reported as CLH), per the amount of preparation that the assay uses: 9 uL/min
The estimate for compound 4 lay 2.0-fold (0.30 log units) above the measured number; measured number inside the range.
By their numbers in this assay, from the lowest: compound 2; then compounds 4, 3 and 1 (each within the scatter of the next).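

For the compounds shown here, the first direct reading at this position, on the aromatic carbon next to the ring nitrogen, is a 1.2-fold lower number from compound 3 to compound 4 (0.09 log units; within the scatter) in this assay when pyridin-4-yl replaces 4-carbamoyl-3-fluorophenyl. On this core, the exchange removes the carbamoyl group with its hydrogen-bond donor and the ring fluorine without a change that can be told from the scatter, so the two groups cannot be separated on this read-out. No supporting data are available to explain this outcome.

Still open, going by these compounds, is whether pyridin-4-yl would leave the number equally undisturbed on the core of compound 2, which gives 2 uL/min with the carbamoyl group in place. On these data alone, it is also open whether a carboxylic acid or a piperazine at this position would stay as close to compound 3.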